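Fluoro to chloro on the aryl piperazine of compound 1

The source may report more compounds than this note shows. Statements on the series, on what has been measured and on what is new or still open speak of the compounds shown alone.

Measured compounds:
compound 1 `CCCn1c(=O)[nH]c2nc(-c3ccc(S(=O)(=O)N4CCN(c5cccc(F)c5)CC4)cc3)[nH]c2c1=O` — 0.632 nM
compound 2 `CCCn1c(=O)c2[nH]c(-c3ccc(S(=O)(=O)N4CCN(c5ccc(Cl)cc5)CC4)cc3)nc2n(C)c1=O` — 1.91 nM
compound 3 `CCCn1c(=O)[nH]c2nc(-c3ccc(S(=O)(=O)N4CCN(c5ccccc5)C(C)C4)cc3)[nH]c2c1=O` — 7.15 nM

In an assay on CHO cells for displacement of a labelled ligand from adenosine receptor A2b (Homo sapiens), read by scintillation counting, with a stated time of 75 min, in the presence of a further agent that is not named here (on this read-out higher numbers stand for weaker inhibition and lower numbers for stronger inhibition), compound 1 gives 0.632 nM, the lowest number of the three. Compound 2 gives 1.91 nM, a higher number that lies beyond the scatter of the read-out, and compound 3 gives 7.15 nM, higher still and likewise beyond the scatter; compound 1 is therefore the strongest inhibitor among the measured set. For the measured compounds named here, compounds 2 and 3 each differ from compound 1 in more than one place, so no single-change step is available from the measured numbers.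

Compound 4 `CCCn1c(=O)[nH]c2nc(-c3ccc(S(=O)(=O)N4CCN(c5cccc(Cl)c5)CC4)cc3)[nH]c2c1=O` has not yet been measured. It differs from compound 1 in one place: chloro in place of fluoro on an aromatic carbon. The change exchanges one halogen for another of the same group, on the same aromatic carbon, with no ring, donor, acceptor or charge count altered.

Going by the values given here, since no measured pair isolates this exchange, the expectation rests on the size of the change alone: a small step in this assay, not clearly beyond the scatter in either direction, is expected from compound 1 to compound 4, a 1.1-fold higher number from compound 1 to compound 4 (0.04 log units; within the scatter). Compound 4 is accordingly estimated at 0.7 nM, with a range of 0.3 nM to 1.6 nM.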

Compound 4, inhibition constant: 0.342 nM
Compound 4: middle estimate off by 2.0-fold (0.31 log units), on the high side, within the range that was stated.
By their numbers in this assay, from the lowest: compounds 4 and 1 (each within the scatter of the next); then compound 2; then compound 3.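

In this assay, chloro in place of fluoro on an aromatic carbon, meta to a large group, gives a 1.8-fold lower number from compound 1 to compound 4 (0.27 log units; within the scatter), the first single-change step available in the series. The read-out therefore does not separate 3-fluorophenyl from 3-chlorophenyl, and at this position the two halogens cannot be ranked on these data, while compound 4 shows that the larger halogen is accepted here with a value in the same sub-scatter range as compound 1. No measurement bears on why the two halogens read alike, and none is available beyond the binding numbers themselves.

A single exchange between two halogens says little about how far this position accepts other groups, so a methoxy group, a trifluoromethyl group, a nitrile, an amine or a carboxylic acid on the same aromatic carbon would test it much more widely than a further halogen. On these data alone, whether the same exchange reads alike on another carbon of this ring, or with bromo or plain hydrogen on this one, also remains open.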